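Swapping the aryl end in a dihydrofolate reductase series

This account rests on a few compounds, and the source may have more. Where it says the series, first, only, none or still open, it means among the compounds named here.

Compound 1 `NC1=NC2(CCSCC2)N(OCCCOc2ccc(Cl)c(Cl)c2)C(N)=N1`: 89.8%
Compound 2 `NC1=NC2(CCOCC2)N(OCCCOc2ccc(Cl)cc2)C(N)=N1`: "not determined" (no result reported)
Compound 3 `NC1=NC2(CCOCC2)N(OCCCOc2ccc(F)cc2)C(N)=N1`: "not determined" (no result reported)

Three compounds share the core of compound 1, and only compound 1 carries a number. In an assay on isolated protein for inhibition of Dihydrofolate reductase (Homo sapiens), read by spectrophotometry, using NADPH, with stated times of 5 s and 6 min, tested at 50 uM (a lower number here means a weaker effect, a higher number a stronger effect of the compound at the concentration tested), compound 1 gives 89.8%, a strong effect at the concentration tested. In this assay compound 2 gives "not determined" (no result reported) and compound 3 gives "not determined" (no result reported), so compound 1 stands alone as the only measured point. Compound 4 `NC1=NC2(CCSCC2)N(OCCCOc2ccccc2Br)C(N)=N1` keeps the core of compound 1 and differs in one place: 2-bromophenyl in place of 3,4-dichlorophenyl on an oxygen on a saturated carbon. For the measured compounds named here, no measured pair shows what such a change does here, so the expected step is small and downward, probably within or only just beyond the usual scatter. Compound 4 is expected to give 80% (range 55% to 95%) in this assay, an expected step of a number 9.8 percentage points lower from compound 1 to compound 4 (within the scatter).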

Compound 4, a percentage reported as inhibition, at one concentration (the size of the read-out at that concentration, not a potency): 89.6%
For compound 4 the middle estimate is 9.6 percentage points below the measured one, within the range that was stated.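

In this assay, for the compounds shown here, 2-bromophenyl in place of 3,4-dichlorophenyl gives a number 0.2 percentage points lower from compound 1 to compound 4 (within the scatter), the only measured pair. It shows that this aryl end can go from two chlorine atoms to one bromine without a step beyond the scatter, although a single concentration gives no potency. Nothing measured here explains why the two read alike.

Steps to compound 2 and compound 3 cannot be read. From the compounds shown here alone, whether an aryl end bearing an amine or a carboxylic acid would keep this effect remains open.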